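Changing the Phenyl Group on an Aromatic Nitrogen

This account rests on a few compounds, and the source may have more. Where it says the series, first, only, none or still open, it means among the compounds named here.

Compound 1 `N#CC1=C(N)Oc2c(N)cc3nc4ccccc4nc3c2C12C(=O)N(Cc1cnnn1-c1ccccc1Cl)c1ccccc12` gives 29800 nM in a functional assay on A549 cells (Homo sapiens) for antiproliferative activity, read by MTT assay, with a stated time of 48 h; on this read-out higher numbers stand for weaker inhibition and lower numbers for stronger inhibition.
Compound 2 `N#CC1=C(N)Oc2c(N)cc3nc4ccccc4nc3c2C12C(=O)N(Cc1cnnn1-c1ccccc1Br)c1ccccc12` gives 27400 nM in this assay.
Compound 3 `N#CC1=C(N)Oc2c(N)cc3nc4ccccc4nc3c2C12C(=O)N(Cc1cnnn1-c1cccc(C(F)(F)F)c1)c1ccccc12` gives 5400 nM in this assay.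

Compound 3 holds the lowest number of the three: the nearest is compound 2, with a 5.1-fold lower number from compound 2 to compound 3 (0.71 log units; beyond the scatter), and compound 1 lies further off, with a 5.5-fold lower number from compound 1 to compound 3 (0.74 log units; beyond the scatter). Compound 4 `CCc1cccc(C)c1-n1nncc1CN1C(=O)C2(C(C#N)=C(N)Oc3c(N)cc4nc5ccccc5nc4c32)c2ccccc21` differs from compound 3 by 2-ethyl-6-methylphenyl in place of 3-(trifluoromethyl)phenyl on an aromatic nitrogen. Among the measured steps, a 1.1-fold lower number from compound 1 to compound 2 (0.04 log units; within the scatter) shows that swapping one halogen for another on this phenyl changed little, while the two steps to compound 3 show that moving from a 2-halophenyl to 3-(trifluoromethyl)phenyl lowered the number modestly. Compound 4 carries none of these groups, so the guide is indirect; part of the gain seen for compound 3 is expected to be lost. In this assay compound 4 is expected to give about 12000 nM, within 4000 nM to 35000 nM. This expectation corresponds to a 2.2-fold higher number from compound 3 to compound 4 (0.35 log units; beyond the scatter).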

Compound 4, half-maximal inhibitory concentration: > 50000 nM
Compound 4 gave a limit, no number; the forecaster's own chance of this, stated with the estimate: 5%; middle value at least 4.1-fold (0.61 log units) from the limit.
By their numbers in this assay, from the lowest: compound 3; then compounds 2 and 1 (each within the scatter of the next). At a limit, above all of these: compound 4.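

Compound 4 reads only as a limit, not as a number: the limit of > 50000 nM in this assay, at which 1 of the 4 values shown sits. This shows that the phenyl group on this ring nitrogen can matter far more than the halogen swap suggested, since 2-ethyl-6-methylphenyl brings an at least 9.2-fold higher number from compound 3 to compound 4 (0.96 log units; beyond the scatter). Against the 2-halophenyl compounds, the floors of an at least 1.8-fold higher number from compound 2 to compound 4 (0.26 log units; that floor lies within the scatter) and an at least 1.6-fold higher number from compound 1 to compound 4 (0.22 log units; that floor lies within the scatter) do not establish a real gap.

The compounds shown cannot separate the share of the ethyl from that of the methyl. On these data alone, how a phenyl carrying an amine or a carboxylic acid would read here also remains open.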